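Swapping a Nitrophenyl Ether for a Butyl Ether

The source may report more compounds than this note shows. Statements on the series, on what has been measured and on what is new or still open speak of the compounds shown alone.

Of the compounds shown here, three built on the shared core have been tested in a functional assay on HCT-116 cells (Homo sapiens) for inhibition, read by sulforhodamine B assay, with a stated time of 48 h, tested at 50 uM; on this read-out lower numbers stand for less inhibition of growth and higher numbers for more inhibition of growth at the one concentration tested. Compound 1 `COc1ccc([C@@H]2C/C(=N/OCc3cn(-c4ccc(Cl)cc4C)nn3)c3cc(CC=C(C)C)c(OC)cc3O2)cc1` gives 20%. Compound 3 `COc1cc2c(cc1CCC(C)C)C(=O)C[C@@H](c1ccc(O)cc1)O2` gives 77%. Compound 2 `COc1cc2c(cc1CC=C(C)C)C(=O)C[C@@H](c1ccc(Oc3cccc([N+](=O)[O-])c3)cc1)O2` gives 46%, the second highest of the three numbers: the nearest is compound 1, which lies lower by a gap beyond the usual scatter, and the furthest is compound 3, which lies higher, again beyond the scatter.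

Compound 4 `CCCCOc1ccc([C@@H]2CC(=O)c3cc(CC=C(C)C)c(OC)cc3O2)cc1` has not yet been measured. It differs from compound 2 in one place: butyl in place of 3-nitrophenyl on an oxygen on an aromatic ring. Within the data shown here, no two measured compounds differ in a single place, so no measured step tells how large such a change tends to be, and compounds 1 and 3 differ from compound 2 in several places at once.

With that in mind, the step of a number 8 percentage points lower from compound 2 to compound 4 (within the scatter) is expected to be a modest move toward less inhibition, not clearly beyond the scatter. Compound 4 is expected to give 38%, with a range from 18% to 60%.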

Compound 4, percent growth inhibition at one concentration: 60%
Beside the measured number, compound 4's estimate is 22 percentage points below it, within the range that was stated.
By their numbers in this assay, from the lowest: compound 1; then compound 2; then compound 4; then compound 3.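

In this assay, among these compounds, this is the first step that changes one place alone, and it gives a number 14 percentage points higher from compound 2 to compound 4 (beyond the scatter). It shows that the group on this oxygen on an aromatic ring need not be aromatic or carry a nitro group: butyl, with no ring and no hydrogen-bond acceptors, can replace 3-nitrophenyl without any loss of growth inhibition at the one concentration tested. No supporting measurement bears on why the number moves in this direction.

This single swap removes the ring and the nitro group together, so the part played by each cannot be separated. From the compounds shown here alone, whether a plain phenyl, a shorter ethyl chain, a longer hexyl chain or a butyl chain ending in an amine would raise or lower the number remains open.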